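Methyl on the amine of compound 2

The source may hold more compounds than are shown below. What is called first, only, known or untested is meant among the compounds shown, and "the series" means these compounds.

Measured in a functional assay on PC-3M cells (Homo sapiens) for inhibition, read by sulforhodamine B assay, with a stated time of 96 h; on this read-out higher numbers stand for weaker inhibition of growth and lower numbers for stronger inhibition of growth
Compound 1 (`NC(c1ccccc1)c1ccc(-c2ncnc3[nH]cnc23)cc1`) gives 32000 nM
Compound 2 (`NC(c1ccc(Cl)cc1)c1ccc(-c2ncnc3[nH]cnc23)cc1`) gives 28000 nM

For the measured compounds named here, compound 2 lies within the scatter of compound 1, and no measured compound stands apart from it. Compound 3 (`CNC(c1ccc(Cl)cc1)c1ccc(-c2ncnc3[nH]cnc23)cc1`) carries methyl in place of hydrogen on an amine nitrogen. Going by the values given here, the one measured step (a 1.1-fold lower number from compound 1 to compound 2 (0.06 log units; within the scatter)) is chloro in place of hydrogen on an aromatic carbon, so no measured step covers this nitrogen. No shift beyond the scatter is therefore expected in this assay, in either direction. The estimated step is modest (a 1.1-fold lower number from compound 2 to compound 3 (0.05 log units; within the scatter)). Compound 3 is expected at 25000 nM (estimated range 10000 nM to 50000 nM).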

Compound 3, concentration for 50% growth inhibition: 16000 nM
Compound 3: the middle estimate sits 1.6-fold (0.19 log units) above what was measured; low and high end bracket the measured number.
By their numbers in this assay, from the lowest: compounds 3, 2 and 1 (each within the scatter of the next).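

In this assay, methyl in place of hydrogen on the amine nitrogen gives a 1.8-fold lower number from compound 2 to compound 3 (0.24 log units; within the scatter). For the compounds shown here, this is the first reading at this nitrogen, and it shows that the position takes a methyl with no shift beyond the scatter. No separate measurement bears on the size of this step. Open, on these data alone, is whether a second methyl, an ethyl or a longer chain on this nitrogen also stays within the scatter. Also open, as far as these compounds go, is whether methyl reads the same on the amine of compound 1.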